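The compounds below may be only part of what the source reports. "The series", "measured", "known", "first", "only" and "open" are said of these compounds alone.

Working notes on the series, all sharing one core and differing in a single group on an aromatic carbon, para to a large group. In a functional assay on J774 cells (Mus musculus) for cytotoxicity, read by resazurin assay (on this read-out lower numbers stand for stronger inhibition and higher numbers for weaker inhibition), compound 1 (`CSc1ccc(-c2ccc(C(O)CCCCCO)cc2)cc1`) gives 24000 nM and compound 2 (`CCOc1ccc(-c2ccc(C(O)CCCCCO)cc2)cc1`) gives 14000 nM. Within the data shown here, these are the only two numbers so far and they lie within the scatter of each other, so compound 2 holds no distinct place.

Next is compound 3 (`CN(C)c1ccc(-c2ccc(C(O)CCCCCO)cc2)cc1`), with dimethylamino in place of ethoxy on an aromatic carbon. Among the measured compounds shown here, one measured step bears on this change, ethoxy in place of methylsulfanyl at the same place, and it gave a 1.7-fold lower number from compound 1 to compound 2 (0.23 log units; within the scatter). For the measured compounds named here, no compound carrying dimethylamino has a number yet, so this single step is the only guide, and it is a weak one. No step beyond the scatter is therefore expected in this assay, and neither direction is favoured. The estimated step is a 1.3-fold higher number from compound 2 to compound 3 (0.11 log units; within the scatter). Compound 3 is expected at 18000 nM, with an estimated range of 8000 nM to 40000 nM.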

Compound 3, half-maximal inhibitory concentration: 28000 nM
For compound 3 the middle estimate is 1.6-fold (0.19 log units) below the measured one, and the stated range covers the measured number.
By their numbers in this assay, from the lowest: compounds 2, 1 and 3 (each within the scatter of the next).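

In this assay, dimethylamino in place of ethoxy gives a 2.0-fold higher number from compound 2 to compound 3 (0.30 log units; within the scatter), and dimethylamino in place of methylsulfanyl gives a 1.2-fold higher number from compound 1 to compound 3 (0.07 log units; within the scatter). The exchange of ethoxy for dimethylamino keeps the count of heavy atoms, donors and acceptors, adds no ring and no net charge, and replaces one oxygen with one nitrogen; at this place on the aromatic ring, methylsulfanyl, ethoxy and dimethylamino are not separated from one another by any step beyond the scatter, and no compound shown goes against this. No measurement of any other kind bears on this result, so the numbers stand without an explanation.

Still open, on these data alone, is whether a group of a different kind at this place, such as a carboxylic acid, a primary amine or a morpholine ring, would give a step beyond the scatter in this assay. Also open, as far as these compounds go, is whether a longer chain, such as butoxy in place of ethoxy, would stay within the scatter of these three compounds or move clear of them.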